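An Ester in Place of the Amide at a Low Starting Number

The compounds below may be only part of what the source reports. "The series", "measured", "known", "first", "only" and "open" are said of these compounds alone.

Compound 1, `CCN(CC)C(=O)C1=C(C)NC(=O)NC1c1ccco1`, shows little inhibition in an assay on membranes from CHO cells for displacement of a labelled ligand from adenosine receptor A1 (Homo sapiens), read by scintillation counting, with a stated time of 60 min, tested at 1 uM (on this read-out lower numbers stand for less inhibition and higher numbers for more inhibition at the one concentration tested (going by the name of the read-out)), where compound 1 gives 11%. Its two close relatives change only the aromatic ring attached to the saturated ring carbon. Compound 2, `CCN(CC)C(=O)C1=C(C)NC(=O)NC1c1cccs1`, gives 13%, and compound 3, `CCN(CC)C(=O)C1=C(C)NC(=O)NC1c1ccsc1`, gives 11%. The step of a number 2 percentage points higher from compound 1 to compound 2 (within the scatter) and the step of no change at the digits printed from compound 1 to compound 3 (within the scatter) both stay within the scatter, as does a number 2 percentage points lower from compound 2 to compound 3 (within the scatter), so compound 1 stands level with compound 3, and all three sit together at a low level of inhibition.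

Compound 4, `CC1=C(C(=O)OCC2CC2)C(c2ccco2)NC(=O)N1`, keeps the furan-2-yl and the shared core but alters the other side of the molecule: cyclopropylmethoxy in place of diethylamino on a carbonyl carbon. None of the three measured steps touches this carbonyl carbon; each concerns the aromatic ring, and each was small. Within the data shown here, there is therefore no measured step that bears directly on this change, and the only guide is that the series so far has not moved beyond the scatter at all. The expectation for compound 4 is thus a step of a number 1 percentage points higher from compound 1 to compound 4 (within the scatter), meaning no change beyond the scatter. Compound 4 is estimated at 12%, with a likely range from 0% to 30%.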

Compound 4, a percentage reported as inhibition, at one concentration (the size of the read-out at that concentration, not a potency): 29%
For compound 4 the middle estimate is 17 percentage points below the measured one; low and high end bracket the measured number.
By their numbers in this assay, from the lowest: compounds 1, 3 and 2 (each within the scatter of the next); then compound 4.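

Until now only the aromatic ring on the saturated ring carbon had been varied, and every step stayed within the scatter. Among these compounds, the change on the carbonyl carbon is the first to go beyond it: in this assay, cyclopropylmethoxy in place of diethylamino gives a number 18 percentage points higher from compound 1 to compound 4 (beyond the scatter), so in this small set the number responds to this position, although the step is only modest and rests on a single pair of compounds. The swap turns the amide into an ester and brings in a three-membered ring, but no information is available here to explain the rise or to say which of these two differences matters.

Compound 4 carries the ester oxygen and the cyclopropyl ring together, so a plain ethoxy group or a cyclopropylmethylamino group on the same carbonyl carbon would be needed to tell them apart. Going by these compounds, it also remains open whether cyclopropylmethoxy gives a similar step with thiophen-2-yl or thiophen-3-yl in place of furan-2-yl, and what a longer chain such as butoxy would do at this position.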